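A few compounds are considered here, and "the series" means these few. Any claim that something is new, unique, unknown or untested is made for them only; others in the source may bear on it.

Working notes on the series, antiproliferative read-out on the cell line.

Compound 1 `CCn1c(C(=O)N(CCC#N)CCC#N)ccc1C(CC)(CC)c1ccc(OCCC(O)(CC)CC)c(C)c1` in an ADME assay on L02 cells (Homo sapiens) for antiproliferative activity, read by MTT assay, with a stated time of 48 h (on this read-out lower numbers stand for stronger inhibition and higher numbers for weaker inhibition), gives 37800 nM. Compound 2 `CCn1c(C(=O)Nc2cccc(C(F)(F)F)c2)ccc1C(CC)(CC)c1ccc(OCCC(O)(CC)CC)c(C)c1` in this assay gives only a limit of the assay, > 50000 nM, and so stands at the upper end of what the measurement resolves rather than at a number. Among the measured compounds shown here, the single measured step between them, an at least 1.3-fold higher number from compound 1 to compound 2 (0.12 log units; that floor lies within the scatter), rests on the limit of > 50000 nM in this assay, at which 1 of the 2 values shown sits, and therefore sets only a floor; both amide substituents so far return weak inhibition of the cells.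

Compound 3 `CCn1c(C(=O)NC(CO)CCO)ccc1C(CC)(CC)c1ccc(OCCC(O)(CC)CC)c(C)c1` differs from compound 2 by 3-hydroxy-1-(hydroxymethyl)propyl in place of 3-(trifluoromethyl)phenyl on an amide-type nitrogen. This is the same position that the measured step changes, and that step did not move the read-out beyond the scatter. On that basis no step beyond the scatter is expected here, in either direction.

Compound 3 is accordingly expected in this assay at about 42000 nM, with a plausible range from 18000 nM to 50000 nM. The step of an at least 1.1-fold lower number from compound 2 to compound 3 (0.07 log units; that floor lies within the scatter) is estimated to stay within the scatter, with a fair chance that only a limit is again reported.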

Compound 3, half-maximal inhibitory concentration: 3040 nM
Beside the measured number, compound 3's estimate is 14-fold (1.14 log units) above it, and the stated range ends above it.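

The substituent on the amide-type nitrogen does move the read-out in this assay: 3-hydroxy-1-(hydroxymethyl)propyl in place of 3-(trifluoromethyl)phenyl gives an at least 16-fold lower number from compound 2 to compound 3 (1.21 log units; beyond the scatter), and the group of compound 3 in place of the group of compound 1 gives a 12-fold lower number from compound 1 to compound 3 (1.09 log units; beyond the scatter). Compound 2 carries only a limit of the assay, so the first of these steps sets a floor and not a size: the limit of > 50000 nM in this assay, at which 1 of the 3 values shown sits. Compound 3 stands apart from both other compounds by steps beyond the scatter, whereas an at least 1.3-fold higher number from compound 1 to compound 2 (0.12 log units; that floor lies within the scatter) does not separate those two, so the position proves sensitive to the change only with the hydroxylated chain.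

The compounds shown leave open whether the lower number goes with the hydroxyl groups themselves, with their number or with the chain that carries them. A 2-hydroxyethyl group, an amine or a carboxylic acid on the same nitrogen would help separate these readings, and a longer hydroxylated chain would show whether the trend continues beyond compound 3.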